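Working notes: pyridin-3-yl step from compound 3

The compounds below may be only part of what the source reports. "The series", "measured", "known", "first", "only" and "open" are said of these compounds alone.

Measured in an ADME assay (liver) for metabolic stability, with Liver microsome (Homo sapiens) as the target, using microsomes; on this read-out higher numbers stand for fast clearance and lower numbers for slow clearance:
compound 1 `c1ccc(CNc2nnc(-c3c[nH]c4ncccc34)o2)cc1` gives 31 mL.min-1.g-1
compound 2 `Fc1ccccc1CNc1nnc(-c2c[nH]c3ncccc23)o1` gives 32 mL.min-1.g-1
compound 3 `Fc1ccc(CNc2nnc(-c3c[nH]c4ncccc34)o2)cc1` gives 47 mL.min-1.g-1

Compound 3 stands within the scatter of the other two: a 1.5-fold higher number from compound 1 to compound 3 (0.18 log units; within the scatter) and a 1.5-fold higher number from compound 2 to compound 3 (0.17 log units; within the scatter). The next step leads to compound 4 `c1cncc(CNc2nnc(-c3c[nH]c4ncccc34)o2)c1`, with pyridin-3-yl in place of 4-fluorophenyl on a saturated chain carbon bound to a nitrogen on an aromatic ring. Among the compounds with values here, no measured step makes this exact exchange, so the evidence is indirect. The nearest steps, a 1.0-fold higher number from compound 1 to compound 2 (0.01 log units; within the scatter) and a 1.5-fold higher number from compound 2 to compound 3 (0.17 log units; within the scatter), both stayed within the scatter. No step beyond the scatter is therefore expected in this assay, and the estimated move is small, a 1.7-fold lower number from compound 3 to compound 4 (0.22 log units; within the scatter). For compound 4 the estimated value is 28 mL.min-1.g-1, with an expected range of 13 mL.min-1.g-1 to 50 mL.min-1.g-1.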

Compound 4, intrinsic clearance in microsomes: < 14 mL.min-1.g-1
Compound 4 was reported as a limit (the forecaster's own chance of this, stated with the estimate: 5%); middle value at least 2.0-fold (0.30 log units) from the limit.
By their numbers in this assay, from the lowest: compounds 1, 2 and 3 (each within the scatter of the next). At a limit, below all of these: compound 4.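

In this assay this position responds to the change of ring: pyridin-3-yl gives steps beyond the scatter against all three carbon-only rings (an at least 3.3-fold lower number from compound 3 to compound 4 (0.52 log units; beyond the scatter)) (an at least 2.2-fold lower number from compound 2 to compound 4 (0.35 log units; beyond the scatter)) (an at least 2.2-fold lower number from compound 1 to compound 4 (0.34 log units; beyond the scatter)), whereas the fluoro exchanges stayed within it. Compound 4 is a limit and not a number, so each of these steps is only a lower bound on the true size: the limit of < 14 mL.min-1.g-1 in this assay, at which 1 of the 4 values shown sits.

Going by these compounds, whether pyridin-4-yl or pyrimidin-5-yl on the same saturated chain carbon would give a similar step stays open. So does whether a saturated ring such as piperidine would be tolerated there.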